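Enlarging the Piperazine on a Fused Aromatic Core

This account rests on a few compounds, and the source may have more. Where it says the series, first, only, none or still open, it means among the compounds named here.

Compound 1, `COc1cc2c(cc1N1CCN(C)CC1)N(C(=O)c1ccc(-c3cccc(C)n3)c3ccccc13)CC2`, gives 25.1 nM in an assay on isolated protein for binding affinity to 5-hydroxytryptamine receptor 1D (Homo sapiens); on this read-out lower numbers stand for stronger inhibition and higher numbers for weaker inhibition.
Compound 2, `COc1cc2c(cc1N1C[C@@H](C)N(C)[C@@H](C)C1)N(C(=O)Nc1cccc(Cl)c1Cl)CC2`, gives 79.4 nM in this assay.

Of these two, compound 1 stands at the lower number, and its gap to compound 2 lies beyond the usual scatter. Compound 3, `CCCN1[C@H](C)CN(c2cc3c(cc2OC)CCN3C(=O)c2ccc(-c3cccc(C)n3)c3ccccc23)C[C@@H]1C`, has not yet been measured. It differs from compound 1 in one place: 3,5-dimethyl-4-propylpiperazin-1-yl in place of 4-methylpiperazin-1-yl on an aromatic carbon. Going by the values given here, no measured pair shows a change of this kind, so the step in this assay is uncertain; a small weakening, or none beyond the scatter, is expected. The step from compound 1 to compound 3 is expected to be a 1.6-fold higher number from compound 1 to compound 3 (0.20 log units; within the scatter). For compound 3 the estimated value is 40 nM, with an expected range from 10 nM to 160 nM.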

Compound 3, inhibition constant: 158 nM
For compound 3 the middle estimate is 4.0-fold (0.60 log units) below the measured one; measured number inside the range.
By their numbers in this assay, from the lowest: compound 1; then compounds 2 and 3 (each within the scatter of the next).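

Swapping 4-methylpiperazin-1-yl for 3,5-dimethyl-4-propylpiperazin-1-yl on this aromatic carbon of the shared core weakens binding in this assay (a 6.3-fold higher number from compound 1 to compound 3 (0.80 log units; beyond the scatter)), so this place on the core does respond to the piperazine's substituents. The larger group still leaves measurable binding, so the change lowers affinity without abolishing it. Nothing shown explains the loss.
Still open, going by these compounds, is whether the two ring methyls, the propyl chain or both account for the step. A 4-propylpiperazin-1-yl group on the same core would help separate these contributions.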